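The source may report more compounds than this note shows. Statements on the series, on what has been measured and on what is new or still open speak of the compounds shown alone.

Measured so far: compound 1 `CCN(CC)CCCNC(=O)c1ccc(C(CC)(CC)c2ccc(OCC(=O)C(C)(C)C)c(C)c2)n1CC` with 22 nM; compound 2 `CCn1c(C(=O)OCc2ccccn2)ccc1C(CC)(CC)c1ccc(OCC(=O)C(C)(C)C)c(C)c1` with > 50000 nM.

In an assay on HL-60 cells for agonist activity at vitamin D3 receptor (Homo sapiens), read by microscopy, with a stated time of 96 h (on this read-out lower numbers stand for an effect already at smaller amounts and higher numbers for an effect only at larger amounts of compound), compound 1 gives 22 nM. Compound 2 reaches only a limit of this assay, > 50000 nM, so for compound 2 no number is known, only this bound; the relevant evidence is the limit of > 50000 nM in this assay, at which 1 of the 2 values shown sits. Among the compounds with values here, the single measured step, an at least 2200-fold higher number from compound 1 to compound 2 (3.35 log units; beyond the scatter), concerns the group on the carbonyl carbon and carries the series from a numeric value to the limit.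

Compound 3 `CCn1c(C(=O)OCc2ccc(F)cc2)ccc1C(CC)(CC)c1ccc(OCC(=O)C(C)(C)C)c(C)c1` is not yet measured. It differs from compound 2 by 4-fluorophenyl in place of pyridin-2-yl on a saturated chain carbon bound to an oxygen next to a carbonyl group. Within the data shown here, no measured step touches this part of the molecule; the one step that exists changes a different group. Both compound 2 and compound 3 keep the ester, and compound 2 with that ester sits at the limit. Compound 3 is therefore expected to stay near that limit, the expected step being a number no higher from compound 2 to compound 3 (the limit leaves the size open). The estimate for compound 3 is 50000 nM, ranging from 15000 nM to 50000 nM, and most likely this assay will again report only a limit.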

Compound 3, half-maximal effective concentration: 9500 nM
Compound 3: the middle estimate sits 5.3-fold (0.72 log units) above what was measured; the whole stated range lies above it.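

In this assay, the group on a saturated chain carbon bound to an oxygen next to a carbonyl group affects the read-out, as 4-fluorophenyl in place of pyridin-2-yl gives an at least 5.2-fold lower number from compound 2 to compound 3 (0.72 log units; beyond the scatter). Compound 2 provides only a limit, which leaves the full size of this step open: the limit of > 50000 nM in this assay, at which 1 of the 3 values shown sits. Keeping the ester therefore does not by itself place a compound at the limit, yet (4-fluorobenzyl)oxy in place of (3-(diethylamino)propyl)amino on the carbonyl carbon still gives a 430-fold higher number from compound 1 to compound 3 (2.64 log units; beyond the scatter), so the amide side chain of compound 1 retains a large lead over the best ester shown.

The compounds shown do not separate the loss of the ring nitrogen from the arrival of the fluorine, and a plain benzyl group on the same oxygen would provide that comparison. Also open, on these data alone, is how much of the lead of compound 1 belongs to the amide link and how much to the diethylamino end, which a (4-fluorobenzyl)amino group on the carbonyl carbon would begin to distinguish.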